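The source may hold more compounds than are shown below. What is called first, only, known or untested is meant among the compounds shown, and "the series" means these compounds.

Measured so far in a functional assay on KYSE-450 cells (Homo sapiens) for inhibition, read by MTT assay, with a stated time of 48 h; on this read-out higher numbers stand for weaker inhibition and lower numbers for stronger inhibition:
- compound 1 (`C/C=C/C(=O)N(Cc1ccc(OC)c([N+](=O)[O-])c1)c1cc(OC)c(OC)c(OC)c1`): 510 nM
- compound 2 (`COc1cc(NCc2ccc(Cl)cc2)cc(OC)c1OC`): > 80000 nM
- compound 3 (`C/C=C/C(=O)N(Cc1ccc(OC)c(OC)c1)c1cc(OC)c(OC)c(OC)c1`): 39100 nM

The entry for compound 2 of > 80000 nM is a limit of the assay and not a number. Within the data shown here, of the two actual numbers, compound 3 holds the higher one at 39100 nM and its only numeric neighbour is compound 1.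

Compound 4 (`C/C=C/C(=O)N(Cc1ccc(OC)c(N)c1)c1cc(OC)c(OC)c(OC)c1`) follows from compound 3, with amino in place of methoxy on an aromatic carbon, ortho to a methoxy group (amino in place of methoxy on an aromatic carbon). Among the measured compounds shown here, the one measured step at that same carbon, methoxy in place of nitro, is large (a 77-fold higher number from compound 1 to compound 3 (1.88 log units; beyond the scatter)). For the measured compounds named here, it is the only guide here, and it shows that the group on this carbon can move the number a long way. With the methoxy gone, a step towards lower numbers and beyond the scatter is therefore expected in this assay, on the evidence of that change (a 77-fold higher number from compound 1 to compound 3 (1.88 log units; beyond the scatter)). Going by these compounds, its size is expected to be substantial, though how close amino comes to nitro is unknown, so the range stays wide.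

For compound 4 the estimate is 1500 nM with an expected range from 200 nM to 12000 nM in this assay.

The expected move is (a 26-fold lower number from compound 3 to compound 4 (1.42 log units; beyond the scatter)).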

Compound 4, half-maximal inhibitory concentration: 310 nM
Compound 4: the middle estimate sits 4.8-fold (0.68 log units) above what was measured; low and high end bracket the measured number.
By their numbers in this assay, from the lowest: compounds 4 and 1 (each within the scatter of the next); then compound 3. At a limit, above all of these: compound 2.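

In this assay, the amino group gives a 130-fold lower number from compound 3 to compound 4 (2.10 log units; beyond the scatter), so the large change at this aromatic carbon is not confined to nitro, whose step to methoxy is a 77-fold higher number from compound 1 to compound 3 (1.88 log units; beyond the scatter). With two different groups now compared with methoxy at the same carbon, methoxy stands apart from both, and the series gains a second group that keeps the number in the range of compound 1. The direct comparison, a 1.6-fold lower number from compound 1 to compound 4 (0.22 log units; within the scatter), does not separate amino from nitro in this assay, and nothing measured here bears on why these two groups match or why methoxy differs.

The compounds shown leave open whether the low numbers require a particular kind of group on this carbon or only the absence of methoxy; hydroxy, fluoro or a plain hydrogen at this place would help to decide that. Also open, going by these compounds, is how far the amino group can be changed at this carbon, for example to a dimethylamino or an acetamido group, while the number stays near that of compound 4.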